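From 2,5-Dimethylphenyl to 3,4-Dimethylphenyl on Compound 1

The source may hold more compounds than are shown below. What is called first, only, known or untested is meant among the compounds shown, and "the series" means these compounds.

Of the compounds shown here, three have been measured in a toxicity assay on HUVEC cells (Homo sapiens) for inhibition (a lower number here means a stronger inhibitor of growth, a higher number a weaker inhibitor of growth), and the starting point of this account is compound 1, `Cc1ccc(C)c(N2CCN(C(=O)c3oc(C)nc3-c3ccccc3)CC2)c1`. Here compound 1 gives 1.73 ug/mL. That number lies within the scatter of compound 2, `CCC[C@H](Nc1nc(-c2ccc(NC(=O)NCC)c(OC)c2)ncc1C)c1cccnc1`, which gives 2.1 ug/mL. Compound 3, `COc1cc(OC)cc(N2CCN(C(=O)c3oc(C)nc3-c3cccc(F)c3)CC2)c1`, gives 0.126 ug/mL, and this number is lower than that of compound 1 by a margin well beyond the scatter. Compound 1 therefore stands in the upper part of this small range, level with compound 2 within the scatter.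

The next compound is compound 4, `Cc1nc(-c2ccccc2)c(C(=O)N2CCN(c3ccc(C)c(C)c3)CC2)o1`, which has not yet been measured. It has 3,4-dimethylphenyl in place of 2,5-dimethylphenyl on an amine nitrogen in a ring.

For the measured compounds named here, no pair of measured compounds differs in one place, so the data hold no measured step for a change of this kind. The expectation must rest mainly on compound 1 at 1.73 ug/mL, and no change beyond the scatter is anticipated in this assay. The expected step is a 1.3-fold lower number from compound 1 to compound 4 (0.12 log units; within the scatter), which is an estimate with no firm direction. For compound 4 the estimated value is 1.3 ug/mL, with an expected range from 0.3 ug/mL to 5 ug/mL.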

Compound 4, concentration for 50% growth inhibition: 3.52 ug/mL
Compound 4: the middle estimate sits 2.7-fold (0.43 log units) below what was measured; measured number inside the range.
By their numbers in this assay, from the lowest: compound 3; then compounds 1, 2 and 4 (each within the scatter of the next, the first and the last beyond it).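

For the compounds shown here, the step is the first measured one-place change in this assay: 3,4-dimethylphenyl in place of 2,5-dimethylphenyl on an amine nitrogen in a ring gives a 2.0-fold higher number from compound 1 to compound 4 (0.31 log units; beyond the scatter) and so points, modestly, toward a weaker inhibitor of growth. The two compounds have the same atoms, and the group that leaves and the group that enters match in heavy atoms, donors, acceptors and charge, so a different arrangement of the same two methyl groups on this phenyl ring is enough to move the number beyond the scatter. Nothing at hand explains why this rearrangement has this result.

The compounds shown leave open whether a single methyl group or a chlorine atom on this phenyl ring would give a number closer to that of compound 1 or that of compound 4. They also leave open whether an unsubstituted phenyl or a phenyl bearing a carboxylic acid at this amine nitrogen would fall inside the span set by this one step in this assay or outside it.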